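A few compounds are considered here, and "the series" means these few. Any claim that something is new, unique, unknown or untested is made for them only; others in the source may bear on it.

Compound 1 `Cc1ccc(C2CNN=C2S(=O)(=O)CC2=NCCS2)cc1` and compound 3 `Cc1ccc(C2CNN=C2S(=O)(=O)CC2=NCCO2)cc1` share a core, and compound 2 `COc1ccc(-c2noc(-c3ccc(C)cc3)c2S(=O)(=O)CC2=NCCS2)cc1` is built on a different core; the difference between the two cores is not broken down here. In a functional assay, read by Griess assay, with a stated time of 150 min, tested at 75 ug/mL (a lower number here means a weaker effect, a higher number a stronger effect of the compound at the concentration tested), compound 1 gives 48.6% and compound 3 gives 49.7%, a step of a number 1.1 percentage points higher from compound 1 to compound 3 (within the scatter) for the change (a group of 5 heavy atoms (3 carbon, 1 nitrogen, 1 oxygen; one five-membered non-aromatic ring with 2 hetero atoms) in place of a group of 5 heavy atoms (3 carbon, 1 nitrogen, 1 sulfur; one five-membered non-aromatic ring with 2 hetero atoms), on a saturated chain carbon bound to a sulfonyl sulfur). Compound 2 is reported in this assay as "not active" (no number reported). Compound 4 `COc1ccc(-c2noc(-c3ccc(C)cc3)c2S(=O)(=O)CC2=NCCO2)cc1` carries the same kind of change on the core of compound 2, namely (a group of 5 heavy atoms (3 carbon, 1 nitrogen, 1 oxygen; one five-membered non-aromatic ring with 2 hetero atoms) in place of a group of 5 heavy atoms (3 carbon, 1 nitrogen, 1 sulfur; one five-membered non-aromatic ring with 2 hetero atoms), on a saturated chain carbon bound to a sulfonyl sulfur). Since the change brought only a number 1.1 percentage points higher from compound 1 to compound 3 (within the scatter) on the other core, a step of about the same small size is expected from compound 2 to compound 4. Compound 4 is therefore expected to show 8% in this assay, roughly between 0% and 25%, and may well again be reported without a number.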

Compound 4, a percentage reported as activity, at one concentration (the size of the read-out at that concentration, not a potency): 73%
For compound 4 the middle estimate is 65 percentage points below the measured one; the whole stated range lies below it.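

In this assay, for the compounds shown here, compound 2 carries no number, so no step to compound 4 can be read. The compounds shown leave open why the same change acts differently on the two cores, and no measurement here bears on that.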